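Chloro on the Benzyl Arm of Compound 1

This account rests on a few compounds, and the source may have more. Where it says the series, first, only, none or still open, it means among the compounds named here.

Measured so far in an assay on HEK293 cells for agonist activity at Toll-like receptor 8 (Homo sapiens), read by a luciferase reporter, with a stated time of 6 h; on this read-out higher numbers stand for an effect only at larger amounts of compound and lower numbers for an effect already at smaller amounts:
compound 1 `CCCCNc1nc(N)nc2c1CN(Cc1ccccc1)CC2` — 0.06 uM
compound 2 `CCCCNc1nc(N)nc2c1CCNC2` — 0.6 uM
compound 3 `CCCCNc1nc(N)nc2c1CCN(C(C)=O)C2` — 0.4 uM

Of the compounds shown here, three sharing one core have been measured in this assay. Compound 1 `CCCCNc1nc(N)nc2c1CN(Cc1ccccc1)CC2` carries a benzyl group on the ring nitrogen and gives 0.06 uM, the lowest of the three numbers, with compound 3 nearest and compound 2 furthest, both beyond the scatter. Compound 2 `CCCCNc1nc(N)nc2c1CCNC2`, with a hydrogen on that nitrogen, gives 0.6 uM, and compound 3 `CCCCNc1nc(N)nc2c1CCN(C(C)=O)C2`, with an acetyl there, gives 0.4 uM. Among the compounds with values here, the one measured step, a 1.5-fold lower number from compound 2 to compound 3 (0.18 log units; within the scatter), concerns the ring nitrogen and not the benzyl ring.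

Compound 4 `CCCCNc1nc(N)nc2c1CN(Cc1ccccc1Cl)CC2` differs from compound 1 by chloro in place of hydrogen on an aromatic carbon. Within the data shown here, no measured step touches a substituent on the benzyl ring, so the data give no direction for this change. Compound 1 gives 0.06 uM, and compound 4 is expected to stay close to it, with no change at the digits printed from compound 1 to compound 4 (within the scatter) and an estimated 0.06 uM in this assay, between 0.02 uM and 0.2 uM.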

Compound 4, minimum effective concentration: 0.05 uM
The estimate for compound 4 lay 1.2-fold (0.08 log units) above the measured number, and the stated range covers the measured number.
By their numbers in this assay, from the lowest: compounds 4 and 1 (each within the scatter of the next); then compounds 3 and 2 (each within the scatter of the next).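

Chloro in place of hydrogen on an aromatic carbon, ortho to a large group, gives a 1.2-fold lower number from compound 1 to compound 4 (0.08 log units; within the scatter) in this assay for this benzyl arm. Within the data shown here, this is the first measured step on the benzyl ring itself, and it shows that going from benzyl to 2-chlorobenzyl keeps the number within the scatter of that of compound 1, so this position can carry a chloro without a measurable change in this read-out. No measurement shown explains this result.

The compounds shown leave open whether this holds only for chloro or also for other groups on the same aromatic carbon, such as methoxy, an amine or a carboxylic acid. They also leave open whether chloro on any other carbon of the benzyl ring would give the same outcome.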